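A few compounds are considered here, and "the series" means these few. Any claim that something is new, unique, unknown or untested is made for them only; others in the source may bear on it.

Measured so far:
Compound 1, `CC(C)C[C@@H]1NC(=O)[C@H](CS)NC1=O`: 83.3%
Compound 2, `CC(C)C[C@@H]1NC(=O)[C@H](C)NC1=O`: 0%
Compound 3, `CC(C)C[C@@H]1NC(=O)[C@H](Cc2cnc[nH]2)NC1=O`: 0%

These three compounds share one core and differ only on a saturated chain carbon bound to a saturated ring carbon. In a functional assay, tested at 2.5 mM (a higher number here means more inhibition at the concentration tested (going by the name of the read-out), a lower number less inhibition), compound 1 gives 83.3%, while compound 3 gives 0%, level with compound 2 at the digits shown and together the lowest of the three numbers. Compound 4, `CC(C)C[C@@H]1NC(=O)[C@H](CCC(=O)O)NC1=O`, has not been measured yet; it carries carboxymethyl in place of 1H-imidazol-5-yl on a saturated chain carbon bound to a saturated ring carbon. The step of no change at the digits printed from compound 2 to compound 3 (within the scatter) shows that swapping one group for another at this place leaves the read-out flat, whereas a number 83.3 percentage points lower from compound 1 to compound 2 (beyond the scatter) and a number 83.3 percentage points lower from compound 1 to compound 3 (beyond the scatter) show that only the sulfanyl compound inhibits. Compound 4 also lacks sulfanyl, so no step beyond the scatter is expected, no change at the digits printed from compound 3 to compound 4 (within the scatter). Compound 4 is therefore estimated to give 0%, between 0% and 15%.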

Compound 4, a percentage reported as inhibition, at one concentration (the size of the read-out at that concentration, not a potency): 0%
Compound 4: the middle estimate sits on the measured number at the digits printed; the range from low to high includes it.
By their numbers in this assay, from the lowest: compounds 2, 3 and 4 (each within the scatter of the next); then compound 1.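

In this assay, carboxymethyl, which has no ring, behaves like 1H-imidazol-5-yl (no change at the digits printed from compound 3 to compound 4 (within the scatter)) and like hydrogen (no change at the digits printed from compound 2 to compound 4 (within the scatter)). Three quite different replacements at this place now give the same reading, and carboxymethyl in place of sulfanyl loses the inhibition just as the other two do (a number 83.3 percentage points lower from compound 1 to compound 4 (beyond the scatter)). Among these four compounds, only the sulfanyl compound inhibits.

Going by these compounds, whether a hydroxyl or a methylsulfanyl group at this place would keep any inhibition remains open. No measurement at hand explains why sulfanyl stands apart.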